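This account rests on a few compounds, and the source may have more. Where it says the series, first, only, none or still open, it means among the compounds named here.

Compound 1 `C1=C(c2cccnc2)C[C@@H]2CNC[C@H]1C2` and compound 2 `CN1C[C@@H]2C=C(c3cccnc3)C[C@@H](C2)C1` share one core and differ in a single spot: methyl in place of hydrogen on an amine nitrogen in a ring. In an in vitro functional assay on SH-SY5Y cells for agonist activity at Neuronal acetylcholine receptor; alpha3/beta4 (Homo sapiens), read by FLIPR and calcium flux (on this read-out higher numbers stand for an effect only at larger amounts of compound and lower numbers for an effect already at smaller amounts), compound 1 gives 73 nM. For compound 2 this assay reports only a limit, > 10000 nM, not an exact number. The step of an at least 130-fold higher number from compound 1 to compound 2 (2.13 log units; beyond the scatter) is therefore known only as a lower bound, as it rests on (the limit of > 10000 nM in this assay, at which 1 of the 3 values shown sits). Compound 3 `CC(C)Oc1cncc(C2=CC3CNCC(C2)C3)c1` carries a different core; how that core differs from the core of compound 1 is not broken down here. In this assay compound 3 gives 69 nM, a value that sits within the scatter of compound 1. Compound 4 `CC(C)Oc1cncc(C2=CC3CC(C2)CN(C)C3)c1` has not yet been measured. It relates to compound 3 exactly as compound 2 relates to compound 1: methyl in place of hydrogen on an amine nitrogen in a ring, at the same place in the same kind of ring. Going by the values given here, the one measured example of this change, an at least 130-fold higher number from compound 1 to compound 2 (2.13 log units; beyond the scatter), was large, so a comparable step is expected for compound 4, namely a 120-fold higher number from compound 3 to compound 4 (2.06 log units; beyond the scatter). On that basis compound 4 is estimated to give about 8000 nM in this assay, and it is quite possible that only a limit, not a number, is reported.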

Compound 4, half-maximal effective concentration: > 10000 nM
Compound 4: no number, only a limit; the forecaster's own chance of this, stated with the estimate: 55%; middle value at least 1.2-fold (0.09 log units) away from the limit.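

In this assay, methyl in place of hydrogen on an amine nitrogen in a ring gives a large step on the second core as well: an at least 140-fold higher number from compound 3 to compound 4 (2.16 log units; beyond the scatter). This step rests on a limit for compound 4, just as the earlier one rests on a limit for compound 2, so neither compound has an exact number and both steps are only lower bounds: the limit of > 10000 nM in this assay, at which 2 of the 4 values shown sit. The change therefore pushes the number far up on both cores, which shows that its large effect carries over within these two pairs, but it does not show that the true size of the step is the same on each core: the same change on two cores in this assay, an at least 130-fold higher number (2.13 log units; beyond the scatter) from compound 1 to compound 2 and an at least 140-fold higher number (2.16 log units; beyond the scatter) from compound 3 to compound 4; the limit leaves it open whether they differ.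

The compounds shown leave open whether an ethyl group or a longer chain on that nitrogen would give a step as large as methyl does. They also leave open whether the same step would appear on any core beyond these two.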